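A few compounds are considered here, and "the series" means these few. Any claim that something is new, unique, unknown or untested is made for them only; others in the source may bear on it.

Measured in an assay for inhibition of Alpha amylase (Homo sapiens), with a stated time of 10 min; on this read-out lower numbers stand for stronger inhibition and higher numbers for weaker inhibition: compound 1 `COc1ccc(OC)c(/C=C2/C(=O)N(c3ccc(Cl)cc3)N=C2C)c1` gives 2130 nM; compound 2 `COc1cc(/C=C2/C(=O)N(c3ccc(Cl)cc3)N=C2C)cc(OC)c1` gives 2210 nM; compound 3 `COc1cc(/C=C2/C(=O)N(c3ccc(Cl)cc3)N=C2C)cc(OC)c1Br` gives 1680 nM.

Compound 3 arises from compound 2 by bromo in place of hydrogen on an aromatic carbon, and this step gave a 1.3-fold lower number from compound 2 to compound 3 (0.12 log units; within the scatter). Compound 1 and compound 2 are built from the same atoms joined differently; the difference between their two cores is not broken down here, and their values lie within the scatter of each other.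

Compound 4 `COc1cc(/C=C2/C(=O)N(c3ccc(Cl)cc3)N=C2C)c(OC)cc1Br`, not yet measured, arises from compound 1 by bromo in place of hydrogen on an aromatic carbon. This is the same kind of change as from compound 2 to compound 3, though the place differs: in compound 3 the bromo is ortho to two methoxy groups, whereas in compound 4 it is ortho to one methoxy group and meta to another. Because a 1.3-fold lower number from compound 2 to compound 3 (0.12 log units; within the scatter) stayed within the scatter, a similar small step is expected for compound 4, namely a 1.3-fold lower number from compound 1 to compound 4 (0.10 log units; within the scatter). Compound 4 is therefore estimated at 1700 nM, likely between 900 nM and 3200 nM.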

Compound 4, half-maximal inhibitory concentration: 1860 nM
Compound 4: middle estimate off by 1.1-fold (0.04 log units), on the low side, within the range that was stated.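

In this assay, bromo in place of hydrogen on an aromatic carbon gave a 1.1-fold lower number from compound 1 to compound 4 (0.06 log units; within the scatter), so on this core too the step stays within the scatter. Set beside the earlier step, the two results do not differ: the same change on two cores in this assay, a 1.3-fold lower number (0.12 log units; within the scatter) from compound 2 to compound 3 and a 1.1-fold lower number (0.06 log units; within the scatter) from compound 1 to compound 4, 1.1-fold (0.06 log units) apart, within the scatter of two such steps. Within the data shown here, this shows that the change carries from one core to the other with no step that can be told from the scatter, but it does not show that bromo has any effect of its own on either core, and two pairs say nothing about other cores.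

The compounds shown leave open whether an amine or a carboxylic acid in place of the bromo would give a step beyond the scatter. They also leave open what a longer chain in place of a methoxy group would do.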